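Lipophilicity from compound 2 to compound 3

A few compounds are considered here, and "the series" means these few. Any claim that something is new, unique, unknown or untested is made for them only; others in the source may bear on it.

Compound 1 `Cc1cc(C(=O)NCc2ccccn2)nn1Cc1cc(Cl)ccc1OCc1ccccc1`: > 3.7 (a limit, not a number)
Compound 2 `Cc1cc(NC(=O)c2c(F)cccc2F)nn1Cc1cc(Cl)ccc1OCc1ccccc1`: > 3.7 (a limit, not a number)

In a physicochemical assay for lipophilicity, at pH 7.4 (on this read-out higher numbers stand for higher lipophilicity and lower numbers for lower lipophilicity), compound 2 gives > 3.7, which is a limit and not a number. The evidence so far is the limit of > 3.7 in this assay, at which 2 of the 2 values shown sit.

Compound 3 `COC(=O)Nc1cc(C)n(Cc2cc(Cl)ccc2OCc2ccccc2)n1` keeps the shared core and changes one group, with methoxy in place of 2,6-difluorophenyl on a carbonyl carbon.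

Among the compounds with values here, the only measured step is a step that the two limits leave unreadable from compound 1 to compound 2. It concerns a different change, so it offers no size to carry over. With the ring leaving and a much smaller group entering, a fall in this assay is expected from the limit of compound 2, > 3.7. The expected step is a number at least 0.30 log units lower from compound 2 to compound 3 (that floor lies within the scatter). For compound 3 the estimated value is 3.4, with an expected range of 2.9 to 4.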

Compound 3, distribution coefficient: > 3.7
Compound 3 was reported as a limit; the forecaster's own chance of this, stated with the estimate: 35%; middle value at least 0.30 log units away from the limit.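

In this assay compound 3 gives > 3.7, which is a limit and not a number. Within the data shown here, no step among compound 1, compound 2 and compound 3 can be read. From the compounds shown here alone, how far each compound lies past this limit stays open, as does the size of any change when methoxy replaces 2,6-difluorophenyl.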